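The compounds below may be only part of what the source reports. "The series", "measured", "known", "first", "only" and "open" are said of these compounds alone.

Measured so far in a functional assay on the whole organism for agonist activity, with Mus musculus as the target; on this read-out higher numbers stand for an effect only at larger amounts of compound and lower numbers for an effect already at smaller amounts:
- compound 1 `CCOC(=O)N(C)CC#CCn1ccnc1` gives > 100 mg/kg as a limit
- compound 2 `CCOC(=O)N(C)C(C)C#CCN1CCCC1` gives > 100 mg/kg as a limit

Compound 2 stands at > 100 mg/kg as a limit and not a number. Compound 1 likewise stands at > 100 mg/kg as a limit and not a number. Among the compounds with values here, the series so far shows only the limit of > 100 mg/kg in this assay, at which 2 of the 2 values shown sit, and offers no measured step between compounds.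

Compound 3 `CCOC(=O)N(C)C(C)C#CCn1ccnc1` is compound 2 with one change 1H-imidazol-1-yl in place of pyrrolidin-1-yl on a saturated chain carbon bound to a triple-bonded carbon that places 1H-imidazol-1-yl in place of pyrrolidin-1-yl on a saturated chain carbon bound to a triple-bonded carbon. Within the data shown here, no measured step is available to size this change in this assay and no shift beyond the scatter is expected in either direction. Among the measured compounds shown here, this expectation rests on compound 2 at > 100 mg/kg as the only reference for the change. The estimated step is a step that the limit leaves unreadable from compound 2 to compound 3 and this is expected to stay within the scatter. For compound 3 the expected value is 150 mg/kg with an estimated range of 50 mg/kg to 400 mg/kg and a report of a limit alone is the likeliest outcome.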

Compound 3, dose for half-maximal effect: > 100 mg/kg
Compound 3 ended at the assay's limit; the forecaster's own chance of this, stated with the estimate: 80%; the middle value lies beyond the limit too.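

The steps from compound 2 to compound 3 and from compound 1 to compound 3 cannot be read in this assay, because all three compounds end at the same limit: the limit of > 100 mg/kg in this assay, at which 3 of the 3 values shown sit.

The compounds shown leave open whether any of them reaches a half-maximal effect in this assay, and how large either change is, the 1H-imidazol-1-yl for pyrrolidin-1-yl or the methyl for hydrogen.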